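Ethylamino for dimethylamino on a benzophenone-bearing triazole core

This account rests on a few compounds, and the source may have more. Where it says the series, first, only, none or still open, it means among the compounds named here.

Measured compounds in a functional assay on the whole organism (strain CF-1) for positive allosteric modulation, with Mus musculus as the target; on this read-out lower numbers stand for an effect already at smaller amounts and higher numbers for an effect only at larger amounts of compound:
- compound 1, `Cc1nnc(CN(C)C)n1-c1ccc(Cl)cc1C(=O)c1ccccc1`: 1.1 mg/kg
- compound 2, `Cc1nnc(CN)n1-c1ccc(Cl)cc1C(O)c1ccccc1`: 3.1 mg/kg

Going by the values given here, of the two numbers so far, compound 1 holds the lower one; compound 2 stands higher, by a gap beyond the usual scatter. Compound 3, `CCNCc1nnc(C)n1-c1ccc(Cl)cc1C(=O)c1ccccc1`, differs from compound 1 only by ethylamino in place of dimethylamino on a saturated chain carbon bound to an aromatic carbon. The two share every atom, joined differently. Among the compounds with values here, no measured pair shows this kind of change, so its size is not known from data. Compound 3 is expected to stay close to compound 1, with a step of a 1.4-fold higher number from compound 1 to compound 3 (0.13 log units; within the scatter), within the scatter. Compound 3 is therefore estimated at 1.5 mg/kg, between 0.6 mg/kg and 4 mg/kg.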

Compound 3, dose for half-maximal effect: 0.6 mg/kg
Beside the measured number, compound 3's estimate is 2.5-fold (0.40 log units) above it; low and high end bracket the measured number.
By their numbers in this assay, from the lowest: compounds 3 and 1 (each within the scatter of the next); then compound 2.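

In this assay, ethylamino in place of dimethylamino on a saturated chain carbon bound to an aromatic carbon gives a 1.8-fold lower number from compound 1 to compound 3 (0.26 log units; within the scatter) and so leaves the read-out unchanged within the scatter. This holds although compound 3 carries a hydrogen-bond donor on this group and compound 1 carries none. No measurement at hand offers an explanation for this result. 

Still open, from the compounds shown here alone, is whether a longer chain such as propylamino or a ring amine such as pyrrolidine at this same place would also hold the read-out.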